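Amino in place of chloro on a fused purine-type core

The source may hold more compounds than are shown below. What is called first, only, known or untested is meant among the compounds shown, and "the series" means these compounds.

Compound 1 `ClCc1ccccc1Cn1cnc2c(Cl)nc(Cl)nc21`: 2880 nM
Compound 2 `Nc1nc(Cl)c2ncn(Cc3ccc(CCl)cc3)c2n1`: 10000 nM
Compound 3 `ClCc1ccccc1Cn1cnc2ncnc(Cl)c21`: 5010 nM

In a functional assay on SF-539 cells (Homo sapiens) for cytotoxicity, read by sulforhodamine B assay, with a stated time of 48 h (on this read-out lower numbers stand for stronger inhibition of growth and higher numbers for weaker inhibition of growth), compound 1 gives 2880 nM, the lowest of the three numbers. Its gap to compound 3 lies within the scatter, so the two cannot be told apart, while compound 2 stands beyond the scatter with a clearly higher number, that is, weaker growth inhibition. Compound 2 already carries an amino group in place of one chloro on the core, though it also differs from compound 1 in the benzyl part, so no single step can be read from it.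

Compound 4 `Nc1nc(Cl)c2ncn(Cc3ccccc3CCl)c2n1` has not yet been measured. It differs from compound 1 in one place: amino in place of chloro on an aromatic carbon. Among the measured compounds shown here, the only hint available is compound 2, whose value of 10000 nM is the weakest seen, and whose amino group matches that of compound 4. On that basis a modest step toward weaker growth inhibition is expected, roughly a 2.3-fold higher number from compound 1 to compound 4 (0.35 log units; beyond the scatter), though it may well fall within the scatter. Compound 4 is therefore estimated at 6500 nM, with a likely range from 2500 nM to 18000 nM.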

Compound 4, concentration for total growth inhibition: 38000 nM
For compound 4 the middle estimate is 5.8-fold (0.77 log units) below the measured one; measured number outside the range, above it.
By their numbers in this assay, from the lowest: compounds 1, 3 and 2 (each within the scatter of the next, the first and the last beyond it); then compound 4.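

Replacing the chloro on the aromatic carbon between two ring nitrogen atoms with amino, and changing nothing else, gives a 13-fold higher number from compound 1 to compound 4 (1.12 log units; beyond the scatter) in this assay, so growth inhibition at this position is far from indifferent to the exchange. Compound 2 could not show this, since its benzyl part also differs from that of compound 1; with the same amino group, compound 2 gives 10000 nM and compound 4 gives 38000 nM, so the amino group alone does not set the number. No accompanying measurement accounts for the loss seen with this exchange.

On these data alone, it remains open whether the loss belongs to amino in particular or would follow any replacement of the chloro on this carbon, a question that a methylamino, dimethylamino or methoxy group there could help to settle. Also open, as far as these compounds go, is whether the chloro group that remains on the core of compound 4 and the chloromethyl group on its benzyl part still matter once the amino group is present, which a methoxy group on the core or a plain methyl group on the benzyl part could test.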